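The source may hold more compounds than are shown below. What is called first, only, known or untested is meant among the compounds shown, and "the series" means these compounds.

Measured compounds:
- compound 1 `Cc1ccccc1S(=O)(=O)Nc1ccc2oc(-c3ccccc3)nc2c1` — an assay on cells for inhibition of HSP60/HSP10 (Homo sapiens), with a stated time of 60 min; a lower number here means a stronger inhibitor, a higher number a weaker inhibitor: > 100000 nM
- compound 2 `O=S(=O)(Nc1ccc2oc(-c3ccccc3)nc2c1)c1ccc(F)c(C(F)(F)F)c1` — this assay: 69000 nM

Compound 1 stands at the edge of what this assay reports: its value of > 100000 nM is a limit of the assay and not a number, as the limit of > 100000 nM in this assay, at which 1 of the 2 values shown sits, notes. Compound 2, which carries a different substituted phenyl on the sulfonyl sulfur, gives a measurable value of 69000 nM in this assay. Among the measured compounds shown here, no step between compound 1 and compound 2 is set out, so the two values show only that compound 2 returns a weak but readable number whereas compound 1 does not.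

Compound 3 `O=S(=O)(Nc1ccc2oc(-c3ccccc3)nc2c1)c1ccc(Cl)c(Cl)c1` is not yet measured. It differs from compound 1 by 3,4-dichlorophenyl in place of 2-methylphenyl on a sulfonyl sulfur.

For the measured compounds named here, no measured step is available to size this change. Since compound 1 sits at a limit, any readable value for compound 3 would count as a gain; the expected step in this assay is an at least 1.6-fold lower number from compound 1 to compound 3 (0.22 log units; that floor lies within the scatter), a modest move toward a measurable number, with a real chance that only a limit is returned again. Compound 3 is expected to give 60000 nM in this assay, within 20000 nM to 150000 nM.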

Compound 3, half-maximal inhibitory concentration: > 100000 nM
Compound 3 was reported as a limit; the forecaster's own chance of this, stated with the estimate: 40%; at least 1.6-fold (0.22 log units) between middle value and limit.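

In this assay compound 3 gives > 100000 nM as a limit and not a number. Among the compounds shown here, compound 1 also sits at a limit, so no step between compound 1 and compound 3 can be read: the limit of > 100000 nM in this assay, at which 2 of the 3 values shown sit. From the compounds shown here alone, whether 3,4-dichlorophenyl in place of 2-methylphenyl on a sulfonyl sulfur shifts the value in either direction stays open.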